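Compound 1 to compound 4: hydroxy on the amide-type nitrogen

A few compounds are considered here, and "the series" means these few. Any claim that something is new, unique, unknown or untested is made for them only; others in the source may bear on it.

In a functional assay on NCI-H460 cells (Homo sapiens) (on this read-out higher numbers stand for weaker inhibition and lower numbers for stronger inhibition), compound 1 (`COc1cc(NC(C)CCCNC(=O)NCCO)c2ncccc2c1`) gives > 100000 nM, which is a limit and not a number. Compound 3 (`COc1cc(NC(C)CCCNC(=O)N(CCO)CCO)c2ncccc2c1`) gives > 100000 nM, also a limit. Compound 2 (`COc1cc(NC(C)CCCNC(=O)NOCc2ccccc2)c2ncccc2c1`) alone has a measured number, at 21000 nM. The series therefore shows (the limit of > 100000 nM in this assay, at which 2 of the 3 values shown sit).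

Compound 4 (`COc1cc(NC(C)CCCNC(=O)NO)c2ncccc2c1`) departs from compound 1 by one change: hydroxy in place of 2-hydroxyethyl on an amide-type nitrogen. This is hydroxy in place of 2-hydroxyethyl on an amide-type nitrogen. The closest guide is the change on the same nitrogen, which gives an at least 4.7-fold lower number from compound 1 to compound 2 (0.67 log units; beyond the scatter). The reverse direction is seen in an at least 4.7-fold higher number from compound 2 to compound 3 (0.67 log units; beyond the scatter). The remaining comparison, a step that the two limits leave unreadable from compound 1 to compound 3, adds nothing on size. With a single measured number in the series, the forecast is loose, and a reading at the limit remains possible.

The expected change is an at least 2.5-fold lower number from compound 1 to compound 4 (0.39 log units; beyond the scatter), a modest move toward a lower number in this assay. For compound 4 the estimated value is 40000 nM, with an expected range of 10000 nM to 100000 nM.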

Compound 4, half-maximal inhibitory concentration: > 100000 nM
Compound 4: no number, only a limit; the forecaster's own chance of this, stated with the estimate: 30%; middle value at least 2.5-fold (0.39 log units) from the limit.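

On the amide-type nitrogen, the oxygen alone does not go with a measured number: hydrogen in place of benzyl on that oxygen gives an at least 4.7-fold higher number from compound 2 to compound 4 (0.67 log units; beyond the scatter). The steps from compound 1 and from compound 3 to compound 4 cannot be read, since both ends of each are limits. Among the four compounds, only compound 2, the one carrying benzyl, has a number, and the others share one limit: the limit of > 100000 nM in this assay, at which 3 of the 4 values shown sit.

Still open, from the compounds shown here alone, is whether benzyl specifically goes with the lower number in this assay, or whether a methoxy or phenethoxy group on the same nitrogen would do the same. Also open, going by these compounds, is whether a benzylamino group on the carbonyl carbon, with no oxygen in the link, would keep the number of compound 2.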